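A few compounds are considered here, and "the series" means these few. Any claim that something is new, unique, unknown or untested is made for them only; others in the source may bear on it.

Of the compounds shown here, three sharing one core have been tested in a functional assay on M21 cells (Homo sapiens) for antiproliferative activity, read by sulforhodamine B assay, with a stated time of 48 h; on this read-out higher numbers stand for weaker inhibition and lower numbers for stronger inhibition. Compound 1 `CCc1ccccc1NS(=O)(=O)c1ccc(N2CCNC2=O)cc1` gives 180 nM in this assay, the highest of the three numbers, meaning the weakest inhibition seen so far. Compound 2 `CCc1cccc(NS(=O)(=O)c2ccc(N3CCNC3=O)cc2)c1` gives 82 nM, and compound 3 `Cc1cccc(NS(=O)(=O)c2ccc(N3CCNC3=O)cc2)c1C` gives 110 nM. Swapping the 2-ethylphenyl for 3-ethylphenyl produced a 2.2-fold lower number from compound 1 to compound 2 (0.34 log units; beyond the scatter), a modest change that lies beyond the scatter. Swapping it for 2,3-dimethylphenyl produced a 1.6-fold lower number from compound 1 to compound 3 (0.21 log units; within the scatter), which stays within the scatter. Between the two swapped compounds the gap is a 1.3-fold higher number from compound 2 to compound 3 (0.13 log units; within the scatter), also within the scatter.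

Compound 4 `Cc1ccc(C)c(NS(=O)(=O)c2ccc(N3CCNC3=O)cc2)c1` has not yet been measured in this assay. The change from compound 1 is 2,5-dimethylphenyl in place of 2-ethylphenyl on a sulfonamide nitrogen. Both earlier steps altered the same 2-ethylphenyl group on the sulfonamide nitrogen, and each moved the number downward, one beyond the scatter and one within it, so a small lowering is the most natural expectation here, though it may well stay inside the scatter. Compound 4 is therefore expected to give about 120 nM, with a likely range from 60 nM to 240 nM. The step this estimate implies is a 1.5-fold lower number from compound 1 to compound 4 (0.18 log units; within the scatter).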

Compound 4, half-maximal inhibitory concentration: 27 nM
Estimate against measurement, compound 4: 4.4-fold (0.65 log units) above; measured number below the stated range.
By their numbers in this assay, from the lowest: compound 4; then compounds 2, 3 and 1 (each within the scatter of the next, the first and the last beyond it).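

Among these compounds, the group on the sulfonamide nitrogen turns out to matter more than the earlier compounds suggested: in this assay, 2,5-dimethylphenyl in place of 2-ethylphenyl gives a 6.7-fold lower number from compound 1 to compound 4 (0.82 log units; beyond the scatter), even though both groups hold the same count of carbon atoms and compounds 1 and 4 have the same atoms, joined differently. Rearrangement alone also separates the two dimethylphenyl compounds, with a 4.1-fold lower number from compound 3 to compound 4 (0.61 log units; beyond the scatter), and compound 4 likewise stands clear of the 3-ethylphenyl compound, with a 3.0-fold lower number from compound 2 to compound 4 (0.48 log units; beyond the scatter), so compound 4 is the most potent of the four, and the way these carbons are arranged on the ring counts for more than any step among the first three compounds showed. Nothing available here explains why this particular arrangement gives stronger inhibition.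

The compounds shown leave open whether the two methyl groups themselves are needed, or whether a chlorine or a methoxy group could stand in place of either one. They also leave open how a longer chain, such as an ethyl or propyl group, would fare in place of either methyl of the 2,5-dimethylphenyl.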